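From methoxy to isopropoxy at the assay limit

The source may hold more compounds than are shown below. What is called first, only, known or untested is meant among the compounds shown, and "the series" means these compounds.

Compound 1 (`COc1ccc(Br)cc1C(C)NC(=O)NS(=O)(=O)c1ccc(C)cc1`), compound 2 (`COc1ccc(Br)cc1C(C)NC(=O)NS(=O)(=O)c1ccccc1`) and compound 3 (`COc1ccc(Br)cc1C(C)NC(=O)NS(=O)(=O)c1ccc(Cl)cc1`) share a core and were measured in a functional assay on thoracic aorta (Rattus norvegicus, strain Wistar), with a stated time of 15 min; a lower number here means that less compound is needed, a higher number that more compound is needed for the effect. Compound 1 gives > 300000 nM, which is a limit of the assay and not a number. Compound 2 gives > 300000 nM, which is also a limit. For the measured compounds named here, compound 3 gives 80900 nM, the only true number of the three.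

Compound 4 (`CC(C)Oc1ccc(Br)cc1C(C)NC(=O)NS(=O)(=O)c1ccccc1`) differs from compound 2 as follows: isopropyl in place of methyl on an oxygen on an aromatic ring. This puts isopropyl in place of methyl on an oxygen on an aromatic ring.

Going by the values given here, no measured step touches that place. The nearest guides are chloro in place of hydrogen on an aromatic carbon, giving an at least 3.7-fold lower number from compound 2 to compound 3 (0.56 log units; beyond the scatter), and chloro in place of methyl, giving an at least 3.7-fold lower number from compound 1 to compound 3 (0.56 log units; beyond the scatter). These are changes elsewhere, and they show only that this series can move off (the limit of > 300000 nM in this assay, at which 2 of the 3 values shown sit). No step beyond the scatter is therefore expected in this assay, although a modestly lower number remains possible. The expected step is a number no higher from compound 2 to compound 4 (the limit leaves the size open). For compound 4 the estimate is 300000 nM, with an expected range from 80000 nM to 600000 nM.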

Compound 4, half-maximal effective concentration: 143000 nM
Compound 4: the middle estimate sits 2.1-fold (0.32 log units) above what was measured; the measured number falls inside the stated range.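

The oxygen on the aromatic ring is a second place where a change moves this series off the assay limit: in this assay, going from methoxy to isopropoxy gives an at least 2.0-fold lower number from compound 2 to compound 4 (0.32 log units; beyond the scatter). Before this, only chloro on an aromatic carbon, in compound 3, had given a true number, so the earlier compounds said nothing about the group on this oxygen. Compound 2 has only a limit and not a number, so this step sets a minimum and its full size stays unknown: the limit of > 300000 nM in this assay, at which 2 of the 4 values shown sit.

The compounds shown leave open what a longer chain such as butyl, or a plain hydroxyl, would do on this oxygen. They also leave open how isopropoxy and chloro behave together in a single compound.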